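The source may report more compounds than this note shows. Statements on the series, on what has been measured and on what is new or still open speak of the compounds shown alone.

Compound 1 `Cc1n[nH]c(-c2ccccc2NCC2=NCCN2)n1` gives in an in vitro functional assay on cells (Fibroblast) for agonist activity at Alpha-1D adrenergic receptor (Homo sapiens) (a higher number here means that more compound is needed for the effect, a lower number that less compound is needed), only a limit, < 5020 nM.
Compound 2 `Cc1nc(-c2ccccc2NCC2=NCCN2)n(C)n1` gives in this assay only a limit, < 5020 nM.
Compound 3 `CCn1cccc1-c1ccccc1NCC1=NCCN1` gives in this assay only a limit, < 100000 nM.

Compound 1 has no definite place among these numbers: its own value is a limit, and the two other values are limits as well, so no order among the three compounds can be read. Compound 4 `Cn1ccnc1-c1ccccc1NCC1=NCCN1` has not been measured yet. It differs from compound 1 by 1-methyl-1H-imidazol-2-yl in place of 3-methyl-1H-1,2,4-triazol-5-yl on an aromatic carbon. For the measured compounds named here, the only step measured between two compounds that differ in one place is a step that the two limits leave unreadable from compound 1 to compound 2, and its size cannot be read, as both ends are limits. What the numbers show is confined to the limit of < 5020 nM in this assay, at which 2 of the 3 values shown sit, and (the limit of < 100000 nM in this assay, at which 1 of the 3 values shown sits), which mark where the limits sit. Going by the values given here, no measured step thus tells how the exchange of one five-membered ring for another would move this assay, in either direction or not at all beyond the scatter. Compound 4 is therefore expected to give 1500 nM in this assay, with a range from 150 nM to 10000 nM. This expectation amounts to a step that the limit leaves unreadable from compound 1 to compound 4.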

Compound 4, half-maximal effective concentration: 200 nM
Compound 4: middle estimate off by 7.5-fold (0.88 log units), on the high side; the range from low to high includes it.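

For the compounds shown here, compound 1 has only a limit in this assay, and compound 4 has a definite value there, so no step from compound 1 to compound 4 can be read. The compounds shown leave open whether 1-methyl-1H-imidazol-2-yl in place of 3-methyl-1H-1,2,4-triazol-5-yl changes the concentration needed, and in which direction.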